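This account rests on a few compounds, and the source may have more. Where it says the series, first, only, none or still open, it means among the compounds named here.

Measured so far:

Compound 2, `COc1ccc(F)c(-c2ncc(COc3cccc([C@@H](CC(=O)O)C4CC4)c3)nc2C=C(C)C)c1`: in a functional assay on HEK293 cells for agonist activity at Free fatty acid receptor 1 (Homo sapiens), read by fluorescence and calcium flux, with a stated time of 1 h (a lower number here means that less compound is needed, a higher number that more compound is needed for the effect), compound 2 gives 9.4 nM.
Compound 1, `COc1ccc(F)c(-c2cnc(COc3cccc([C@@H](CC(=O)O)C4CC4)c3)nc2C2=CCCC2(C)C)c1`: in this assay compound 1 gives 12.4 nM.

Compound 2 has the lower of the two numbers, but the gap to compound 1 lies within the scatter, so the two cannot be told apart on these data. Compound 3, `CCCCc1nc(COc2cccc([C@@H](CC(=O)O)C3CC3)c2)cnc1-c1cc(OC)ccc1F`, has not been measured in this assay. It differs from compound 2 in one place: butyl in place of 2-methylprop-1-en-1-yl on an aromatic carbon. The change keeps the heavy-atom count and removes the double bond outside aromatic rings, and the whole of the rest of compound 2 is retained. Among the compounds with values here, no measured pair shows such a step, so the size is uncertain, but a saturated chain of the same length is expected to leave the value near that of compound 2, with a step from compound 2 to compound 3 of a 1.4-fold higher number from compound 2 to compound 3 (0.14 log units; within the scatter), not beyond the scatter. Compound 3 is therefore estimated at 13 nM, with a range from 5 nM to 35 nM.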

Compound 3, half-maximal effective concentration: 2.5 nM
Compound 3: middle estimate off by 5.2-fold (0.72 log units), on the high side, outside the stated range (below it).
By their numbers in this assay, from the lowest: compound 3; then compounds 2 and 1 (each within the scatter of the next).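

In this assay, butyl in place of 2-methylprop-1-en-1-yl on this aromatic carbon, next to the ring nitrogen and ortho to the 2-fluoro-5-methoxyphenyl group, gives a 3.8-fold lower number from compound 2 to compound 3 (0.58 log units; beyond the scatter), a modest step. The two groups have the same heavy-atom count and neither has a ring, yet the value moves beyond the scatter, so this position responds to more than the number of heavy atoms in the chain. Within the data shown here, compound 1 and compound 2 could not show this, as no single-place step joined them.

Nothing in the data accounts for the step.

As far as these compounds go, this is a single pair, so the trend with chain length remains open. Whether propyl or pentyl would match butyl here, or whether a propoxy group would hold the value, cannot be said from these compounds.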